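This account rests on a few compounds, and the source may have more. Where it says the series, first, only, none or still open, it means among the compounds named here.

Measured in a physicochemical assay for acid dissociation:
- compound 1 `COc1ccc(F)cc1CNCCCNc1ccnc2cc(Cc3ccc(C#N)cc3)ccc12` gives 9.47
- compound 2 `COc1cccc(CNCCCNc2ccnc3cc(Cc4cccc(C(F)(F)F)c4)ccc23)c1O` gives 9.47
- compound 3 `COc1ccc(Oc2ccc3c(NCCCNCc4cccc(OC)c4O)ccnc3c2)cc1` gives 9.28

Compound 3 stands at 9.28, and the values of compound 1 and compound 2 both lie within the scatter of it. The three numbers therefore form a single tight group.

The next compound to be measured is compound 4 `COc1cccc(CNCCCNc2ccnc3cc(Cc4ccc(C#N)cc4)ccc23)c1O`. It differs from compound 3 at one site, with 4-cyanobenzyl in place of 4-methoxyphenoxy on an aromatic carbon. That carbon sits on a six-membered aromatic ring of carbon only, part of a fused or bridged system of two rings.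

Among the compounds with values here, only one measured step touches this site: a number 0.19 log units lower from compound 2 to compound 3 (within the scatter). It exchanged a substituted benzyl group for the same 4-methoxyphenoxy group that leaves here, and it stayed within the scatter. Compound 1 carries the entering 4-cyanobenzyl group, though with a different remainder, and gives 9.47. Neither observation points to a real shift, so no step beyond the scatter is expected in this assay, and no direction can be claimed with confidence.

The expected change is small: a number 0.14 log units higher from compound 3 to compound 4 (within the scatter).

For compound 4 the estimated value is 9.42, with an expected range of 9.15 to 9.7.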

Compound 4, acid dissociation constant: 9.47
Beside the measured number, compound 4's estimate is 0.05 log units below it, within the range that was stated.
By their numbers in this assay, from the lowest: compounds 3, 1, 2 and 4 (each within the scatter of the next).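

Notes on the series: in this assay, 4-cyanobenzyl in place of 4-methoxyphenoxy on this aromatic carbon gives a number 0.19 log units higher from compound 3 to compound 4 (within the scatter) and so adds a second replacement at this position that stays inside the scatter. The other two sites can now each be read alone, with 4-cyanophenyl in place of 3-(trifluoromethyl)phenyl on the saturated chain carbon bound to an aromatic carbon giving no change at the digits printed from compound 2 to compound 4 (within the scatter) and 2-hydroxy-3-methoxyphenyl in place of 5-fluoro-2-methoxyphenyl on the saturated chain carbon bound to an amine nitrogen giving no change at the digits printed from compound 1 to compound 4 (within the scatter) as well. No measurement at hand offers an explanation for these numbers.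

On these data alone, every group seen so far at this aromatic carbon carries a six-membered aromatic ring of carbon only, so how a carboxylic acid or a morpholine would read there remains open. Also open, as far as these compounds go, is whether a longer chain between the amine nitrogens would give a step beyond the scatter, and which proton in these compounds the read-out follows.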